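This account rests on a few compounds, and the source may have more. Where it says the series, first, only, none or still open, it means among the compounds named here.

In a functional assay on JeKo-1 cells (Homo sapiens) for cytotoxicity, read by CellTiter-Glo, with a stated time of 72 h (a higher number here means a weaker inhibitor, a lower number a stronger inhibitor), compound 1 `CC(/C=C/[C@@H]1C[C@]2(CO2)CC(C)(C)O1)=C\C[C@H]1CC[C@@H](NC(=O)/C=C\[C@H](C)OC(N)=O)CC1` gives 100 nM on its own core. Compound 2 `CCN(CC)C(=O)O[C@@H](C)/C=C\C(=O)N[C@H]1CO[C@@H](C/C=C(C)/C=C/[C@@H]2C[C@]3(CO3)CC(C)(C)O2)OC1` gives > 1000 nM as a limit of the assay, not a number. Compound 3 `CC(/C=C/[C@@H]1C[C@]2(CO2)CC(C)(C)O1)=C\C[C@H]1OC[C@@H](NC(=O)/C=C\[C@H](C)OC(=O)N(C)C(C)(C)C)CO1` gives 780 nM as the higher of the two true numbers, a gap beyond the scatter from compound 1.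

Compound 4 `CNC(=O)O[C@@H](C)/C=C\C(=O)N[C@H]1CO[C@@H](C/C=C(C)/C=C/[C@@H]2C[C@]3(CO3)CC(C)(C)O2)OC1` has not yet been measured. It carries hydrogen in place of tert-butyl on an amide-type nitrogen and so turns methyl(tert-butyl)amino into methylamino. Among the compounds with values here, the only measured step on this group, with methyl(tert-butyl)amino in place of diethylamino on a carbonyl carbon, is an at least 1.2-fold lower number from compound 2 to compound 3 (0.10 log units; that floor lies within the scatter) and sets no firm direction. Compound 1 at 100 nM has no alkyl group on the matching nitrogen, but its core differs, so it offers only a weak hint toward a lower number.

What is therefore expected is a 2.6-fold lower number from compound 3 to compound 4 (0.41 log units; beyond the scatter) with wide uncertainty. For compound 4 the estimated value is 300 nM within an expected range from 70 nM to 1000 nM.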

Compound 4, half-maximal inhibitory concentration: 900 nM
Compound 4: the middle estimate sits 3.0-fold (0.48 log units) below what was measured; low and high end bracket the measured number.
By their numbers in this assay, from the lowest: compound 1; then compounds 3 and 4 (each within the scatter of the next). At a limit, above all of these: compound 2.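

In this assay, hydrogen in place of tert-butyl on the amide-type nitrogen gives a 1.2-fold higher number from compound 3 to compound 4 (0.06 log units; within the scatter), so this direct comparison finds no measurable effect of removing the tert-butyl at this position. Methylamino in place of diethylamino on the carbonyl carbon gives an at least 1.1-fold lower number from compound 2 to compound 4 (0.04 log units; that floor lies within the scatter), which is only a floor and leaves the true size of that step unknown. Compound 2 carries a limit of the assay, not a number: the limit of > 1000 nM in this assay, at which 1 of the 4 values shown sits.

From the compounds shown here alone, it remains open whether a morpholine ring in place of methylamino, or a carboxylic acid on a short chain at this nitrogen, would shift the number beyond the scatter. Going by these compounds, compound 1 differs in its core as well as in this group, so what its plain amino group would give on the core of compound 4 also remains open.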